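The compounds below may be only part of what the source reports. "The series", "measured", "known", "first", "only" and "open" are said of these compounds alone.

In a toxicity assay on MT2 cells (Homo sapiens) for cytotoxicity (a lower number here means that less compound is tolerated, a higher number that more compound is tolerated), compound 2 (`Cc1nc(C)c([C@H](OC(C)(C)C)C(=O)O)c(N2CCC(C)(C)CC2)c1-c1ccc2c(c1)CCN(c1ncnc3c1cnn3C)C2`) gives >= 17000 nM as a limit, not a number. Compound 1 (`Cc1cccc(F)c1CN1CCc2cc(-c3c(C)nc(C)c([C@H](OC(C)(C)C)C(=O)O)c3N3CCC(C)(C)CC3)ccc2C1`) gives >= 24000 nM as a limit too. Compound 2 therefore has no exact position in the series. Compound 3 (`Cc1nc(C)c([C@H](OC(C)(C)C)C(=O)O)c(N2CCC(C)(C)CC2)c1-c1ccc2c(c1)CCN(c1nccc(-c3cnccn3)n1)C2`) carries a group of 12 heavy atoms (8 carbon, 4 nitrogen; 2 six-membered aromatic rings with 2 hetero atoms each) in place of a group of 10 heavy atoms (6 carbon, 4 nitrogen; one five-membered aromatic ring with 2 hetero atoms, one six-membered aromatic ring with 2 hetero atoms), on an amine nitrogen in a ring when set against compound 2. Among the compounds with values here, the one measured step at this amine nitrogen is a step that the two limits leave unreadable from compound 1 to compound 2 and so gives no size to carry over. Both groups measured there, however, ended at limits of similar height, and compound 2 with >= 17000 nM remains the nearest guide. The expected change is a step that the limit leaves unreadable from compound 2 to compound 3 in this assay, with no step beyond the scatter in either direction. Compound 3 is estimated at 20000 nM, with an expected range from 9000 nM to 40000 nM, and a report as a limit alone is likely.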

Compound 3, half-maximal cytotoxic concentration: >= 17000 nM
Compound 3: only a limit was reported (the forecaster's own chance of this, stated with the estimate: 70%); the middle value is on the limit's open side.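

Within the data shown here, compound 1, compound 2 and compound 3 all stand as limits in this assay, so no step among them can be read. The compounds shown leave open where their exact values lie, and whether the groups on the amine nitrogen in a ring differ at all in this assay.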